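The source may report more compounds than this note shows. Statements on the series, on what has been measured and on what is new or still open speak of the compounds shown alone.

Compound 1 `C=CC(=O)NCC#Cc1ccc2ncn(-c3ccnc(N)n3)c2c1` is measured in an assay on Sf9 cells for inhibition of mitogen-activated protein kinase kinase kinase 14 variant S549D (Homo sapiens), with a stated time of 30 min, in the presence of a further agent that is not named here (on this read-out higher numbers stand for weaker inhibition and lower numbers for stronger inhibition), where compound 1 gives 6310 nM. On the three numbers shown, compound 1 stands level with compound 3 `C#Cc1cncc(C#Cc2ccc3ncn(-c4ccnc(N)n4)c3c2)n1`, which in this assay gives 6310 nM, the two together holding the lowest numbers, while compound 2 `C#Cc1cc(C#Cc2ccc3ncn(-c4ccnc(N)n4)c3c2)ncn1` in this assay gives 50100 nM. The account follows the step from compound 1 to compound 4 `C#Cc1cnc(C#Cc2ccc3ncn(-c4ccnc(N)n4)c3c2)nc1`.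

a group of 8 heavy atoms (6 carbon, 2 nitrogen; one six-membered aromatic ring with 2 hetero atoms) in place of a group of 6 heavy atoms (4 carbon, 1 nitrogen, 1 oxygen; no ring), on a triple-bonded carbon

Two measured steps carry the same kind of change at the same place and bear on it: a 7.9-fold higher number from compound 1 to compound 2 (0.90 log units; beyond the scatter), whereas no change at the digits printed from compound 1 to compound 3 (within the scatter). Between the two entering rings, a 7.9-fold lower number from compound 2 to compound 3 (0.90 log units; beyond the scatter), so the outcome of this replacement depends on which six-membered aromatic ring with 2 hetero atoms enters, and compound 4 carries a third arrangement of such a ring that has not been measured. The chemist therefore expects a step in this assay lying between those two outcomes, most likely a modest rise in the number. For compound 4 the chemist estimates 12600 nM in this assay, with a range from 4000 nM to 50000 nM. That estimate means an expected 2.0-fold higher number from compound 1 to compound 4 (0.30 log units; within the scatter).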

Compound 4, half-maximal inhibitory concentration: 25100 nM
Compound 4: middle estimate off by 2.0-fold (0.30 log units), on the low side; low and high end bracket the measured number.
By their numbers in this assay, from the lowest: compounds 1 and 3 (each within the scatter of the next); then compounds 4 and 2 (each within the scatter of the next).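

Compound 4 shows in this assay that the arrangement in compound 2 is not the only one to fall short of the ((vinylcarbonyl)amino)methyl group, with a 4.0-fold higher number from compound 1 to compound 4 (0.60 log units; beyond the scatter) on this triple-bonded carbon. For the compounds shown here, of the three ring arrangements, only that of compound 3 stays level with compound 1, and a 4.0-fold higher number from compound 3 to compound 4 (0.60 log units; beyond the scatter) confirms that the outcome at this place turns on the arrangement of the entering ring. Compound 4 and compound 2 stand together, with a 2.0-fold lower number from compound 2 to compound 4 (0.30 log units; within the scatter) marking no real separation between their two arrangements.

On these data alone, whether an amine or a carboxylic acid on this triple-bonded carbon would give a lower number than compound 1 and compound 3 stays open. No measurement at hand explains why the three ring arrangements differ.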